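A few compounds are considered here, and "the series" means these few. Any claim that something is new, unique, unknown or untested is made for them only; others in the source may bear on it.

Values in a toxicity assay on NIH3T3 cells (Mus musculus) for cytotoxicity, read by resazurin assay; on this read-out higher numbers stand for an effect only at larger amounts of compound and lower numbers for an effect already at smaller amounts:

- Compound 1 `CC(=O)c1ccc(NCc2cncn2Cc2ccc(-c3ccccc3)cc2)cc1-c1ccccc1` gives > 10000 nM, a limit and not a number
- Compound 2 `COC(=O)c1ccc(NCc2cncn2Cc2ccccc2C)cc1-c1ccccc1` gives 10000 nM
- Compound 3 `COC(=O)c1ccc(NCc2cncn2Cc2ccccc2N)cc1-c1ccccc1` gives 25000 nM

Compound 1 has no exact value, and its result stands as the limit of > 10000 nM in this assay, at which 1 of the 3 values shown sits. Compound 4 `c1ccc(-c2ccc(Cn3cncc3CNc3ccc(-c4nc5ccccc5s4)c(-c4ccccc4)c3)cc2)cc1` keeps the core of compound 1 and exchanges one group, with 1,3-benzothiazol-2-yl in place of acetyl (1,3-benzothiazol-2-yl in place of acetyl on an aromatic carbon). Among the compounds with values here, only one measured step is available, a 2.5-fold higher number from compound 2 to compound 3 (0.40 log units; beyond the scatter), and it is modest. It exchanges a different pair of groups, so it offers only a rough idea of how far a single exchange can move the number in this assay. Within the data shown here, no measured step involves acetyl or 1,3-benzothiazol-2-yl. All three results show an effect only at large amounts of compound, so no step beyond the usual scatter is expected here. The estimated step is a step that the limit leaves unreadable from compound 1 to compound 4. For compound 4 the expected value is 12000 nM, with an estimated range from 4000 nM to 35000 nM. The assay may again report only a limit.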

Compound 4, half-maximal effective concentration: > 1000 nM
Compound 4: only a limit was reported; the forecaster's own chance of this, stated with the estimate: 50%; the middle value is on the limit's open side.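

Within the data shown here, compound 1 gives > 10000 nM and compound 4 gives > 1000 nM in this assay; both are limits and not numbers, so no step between these two compounds can be read. The compounds shown leave open how far 1,3-benzothiazol-2-yl in place of acetyl moves the number.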